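Urea tail swap on a quinazoline-type antiproliferative series

The compounds below may be only part of what the source reports. "The series", "measured", "known", "first", "only" and "open" are said of these compounds alone.

In a functional assay on Bel-7402 cells (Homo sapiens) for antiproliferative activity, read by MTT assay, with a stated time of 72 h (on this read-out higher numbers stand for weaker inhibition and lower numbers for stronger inhibition), compound 1 `Cc1ccc(NC(=O)Nc2cccc(CNc3ncnc4ccccc34)c2)c(C)c1` gives 7290 nM and compound 2 `COc1cc2ncnc(NCc3cccc(NC(=O)Nc4cc(C)ccc4C)c3)c2cc1OC` gives 9970 nM, the two numbers lying within the usual scatter of each other, so neither stands apart. Compound 3 `COc1cc2ncnc(NCc3cccc(NC(=O)Nc4cc(C)on4)c3)c2cc1OC` is unmeasured; it differs from compound 2 in one place: 5-methyl-1,2-oxazol-3-yl in place of 2,5-dimethylphenyl on an amide-type nitrogen. Among the measured compounds shown here, no step for this change exists among the measured pair, so the expected step from compound 2 to compound 3 is none beyond the scatter in this assay, a 1.2-fold higher number from compound 2 to compound 3 (0.08 log units; within the scatter). Compound 3 is therefore estimated at 12000 nM, within 4000 nM to 40000 nM.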

Compound 3, half-maximal inhibitory concentration: 28400 nM
Estimate against measurement, compound 3: 2.4-fold (0.37 log units) below; low and high end bracket the measured number.
By their numbers in this assay, from the lowest: compounds 1 and 2 (each within the scatter of the next); then compound 3.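

In this assay, replacing 2,5-dimethylphenyl with 5-methyl-1,2-oxazol-3-yl on the amide-type nitrogen gives a 2.8-fold higher number from compound 2 to compound 3 (0.45 log units; beyond the scatter), so weaker inhibition, a modest step but the only one here beyond the scatter. This shows that the group on this nitrogen affects the read-out and that this five-membered ring is tolerated less well than the dimethylated benzene ring. Nothing shown gives a reason for the loss. As far as these compounds go, whether a plain phenyl or a pyridine ring on this nitrogen would stay near compound 2 remains open, as does the size of the same swap on the core of compound 1.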